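The source may report more compounds than this note shows. Statements on the series, on what has been measured and on what is new or still open speak of the compounds shown alone.

Measured so far in a physicochemical assay for solubility, in simulated intestinal fluid, measured as thermodynamic solubility, at pH 6.8; a lower number here means a less soluble compound, a higher number a more soluble compound:
- Compound 1 `NC1CCN(c2nc3c(c(Nc4ccc(C(F)(F)F)cc4)n2)CCN(c2ncccc2C(F)(F)F)CC3)C1`: > 215 ug/mL (a limit of the assay, not a number)
- Compound 2 `CN(c1nc2c(c(Nc3ccc(C(F)(F)F)cc3)n1)CCN(c1ncccc1C(F)(F)F)CC2)C1CCCNC1`: 211 ug/mL
- Compound 3 `CNC1CCN(c2nc3c(c(Nc4ccc(C(F)(F)F)cc4)n2)CCN(c2ncccc2C(F)(F)F)CC3)C1`: 233 ug/mL

For the measured compounds named here, only two of these readings are exact numbers, and the one for compound 2 lies within the usual scatter of the other. The gap between them is a 1.1-fold higher number from compound 2 to compound 3 (0.04 log units; within the scatter). The comparison with the limit gives an at least 1.0-fold lower number from compound 1 to compound 2 (0.00 log units; that floor lies within the scatter).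

Compound 4 `FC(F)(F)c1ccc(Nc2nc(NC3CCCNC3)nc3c2CCN(c2ncccc2C(F)(F)F)CC3)cc1` is compound 2 with a single change: hydrogen in place of methyl on a nitrogen on an aromatic ring. This places hydrogen in place of methyl on a nitrogen on an aromatic ring. The closest measured parallel runs the opposite way, with methyl in place of hydrogen on an amine nitrogen, but its size cannot be read: a step that the limit leaves unreadable from compound 1 to compound 3. Going by the values given here, the only step between two exact numbers, a 1.1-fold higher number from compound 2 to compound 3 (0.04 log units; within the scatter), stays within the scatter, so no shift beyond the scatter is expected in this assay.

The expected change is a 1.1-fold higher number from compound 2 to compound 4 (0.03 log units; within the scatter). For compound 4 the estimated value is 225 ug/mL, with an expected range from 130 ug/mL to 380 ug/mL.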

Compound 4, solubility: 203 ug/mL
Beside the measured number, compound 4's estimate is 1.1-fold (0.04 log units) above it; the range from low to high includes it.
By their numbers in this assay, from the lowest: compounds 4, 2 and 3 (each within the scatter of the next).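

For the compounds shown here, replacing methyl with hydrogen on the nitrogen on an aromatic ring leaves the reading in this assay within the scatter (a 1.0-fold lower number from compound 2 to compound 4 (0.02 log units; within the scatter)), so at this position the one carbon of the methyl makes no readable difference, whereas the earlier compounds offered no exact step for this change. Exchanging the 3-(methylamino)pyrrolidin-1-yl group for (piperidin-3-yl)amino also stays within the scatter (a 1.1-fold lower number from compound 3 to compound 4 (0.06 log units; within the scatter)), so these two amine groups cannot be told apart here. Compound 1 is a limit of the assay and not a number, and its step gives only a floor (an at least 1.0-fold lower number from compound 1 to compound 4 (0.02 log units; that floor lies within the scatter)).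

On these data alone, it remains open whether an ethyl group or a longer chain on that nitrogen would read any differently in this assay. The same holds for a carboxylic acid in place of the (piperidin-3-yl)amino group.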